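The source may hold more compounds than are shown below. What is called first, only, known or untested is meant among the compounds shown, and "the series" means these compounds.

Measured in a functional assay (trachea) with Cavia porcellus as the target; on this read-out higher numbers stand for an effect only at larger amounts of compound and lower numbers for an effect already at smaller amounts:
compound 3 `C=CCCn1cnc2c1c(=O)n(C)c(=O)n2CCC` — 16800 nM
compound 1 `CCCn1c(=O)n(CCCO)c(=O)c2[nH]cnc21` — 5100 nM
compound 2 `CCCn1c(=O)n(CCCOC)c(=O)c2[nH]cnc21` — 2900 nM

Compound 3 stands highest of the three in this assay: compound 1 lies nearest and compound 2 furthest, both gaps beyond the scatter. Compound 4 `CCCn1c(=O)n(C)c(=O)c2c1ncn2CCOCC` differs from compound 3 by ethoxy in place of vinyl on a saturated chain carbon, two bonds along the chain from an aromatic nitrogen. Going by the values given here, the only measured step that introduces an ether into a chain is a 1.8-fold lower number from compound 1 to compound 2 (0.25 log units; within the scatter), and it sits on a different chain of the shared core, so it bears on the present change only loosely. Among the compounds with values here, no measured step removes a double bond. On that basis no shift beyond the scatter is expected, with the direction left open. Compound 4 is estimated at 12000 nM (range 5000 nM to 30000 nM). That amounts to an expected step of a 1.4-fold lower number from compound 3 to compound 4 (0.15 log units; within the scatter).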

Compound 4, half-maximal effective concentration: 4600 nM
Compound 4: the middle estimate sits 2.6-fold (0.42 log units) above what was measured; measured number outside the range, below it.
By their numbers in this assay, from the lowest: compounds 2, 4 and 1 (each within the scatter of the next); then compound 3.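

In this assay, ethoxy in place of vinyl on a saturated chain carbon, two bonds along the chain from an aromatic nitrogen, gives a 3.7-fold lower number from compound 3 to compound 4 (0.56 log units; beyond the scatter). Going by these compounds alone, this is the first step beyond the scatter, and it shows that the chain on this aromatic nitrogen responds to a change of group. Nothing available accounts for the shift.

From the compounds shown here alone, the step swaps a double bond for an ether oxygen in one move, so the contribution of each remains open. A butyl or pentyl chain at this position would separate the two.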